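The compounds below may be only part of what the source reports. "The series", "measured", "known", "first", "only" and "open" are said of these compounds alone.

Compound 1 (`CN1CCN(c2cccc(NC(=O)c3nn[nH]n3)c2C#N)CC1`): 0.2 mg/kg
Compound 2 (`COc1cccc(NC(=O)c2nn[nH]n2)c1C(N)=O`): 0.2 mg/kg

In a functional assay on the whole organism for inhibition, with Rattus norvegicus as the target (on this read-out lower numbers stand for an effect already at smaller amounts and higher numbers for an effect only at larger amounts of compound), compound 2 gives 0.2 mg/kg, level with compound 1 within the scatter. Compound 3 (`CN1CCN(c2cccc(NC(=O)c3nn[nH]n3)c2C(N)=O)CC1`) keeps the carbamoyl group of compound 2 but has 4-methylpiperazin-1-yl in place of methoxy on an aromatic carbon. Within the data shown here, no measured pair isolates this change. Compound 1 already carries 4-methylpiperazin-1-yl and gives 0.2 mg/kg, so no step beyond the scatter is expected in this assay, in either direction. The expected change is no change at the digits printed from compound 2 to compound 3 (within the scatter). For compound 3 the estimated value is 0.2 mg/kg, with an expected range of 0.07 mg/kg to 0.6 mg/kg.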

Compound 3, dose for half-maximal effect: 2.3 mg/kg
Compound 3: middle estimate off by 12-fold (1.06 log units), on the low side; the whole stated range lies below it.
By their numbers in this assay, from the lowest: compounds 1 and 2 (each within the scatter of the next); then compound 3.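

In this assay, 4-methylpiperazin-1-yl in place of methoxy on the aromatic carbon ortho to a carbamoyl group gives a 12-fold higher number from compound 2 to compound 3 (1.06 log units; beyond the scatter), so that group is not interchangeable with methoxy when carbamoyl is present. With 4-methylpiperazin-1-yl kept, carbamoyl in place of cyano gives a 12-fold higher number from compound 1 to compound 3 (1.06 log units; beyond the scatter), so the higher number appears only where the two groups occur together among these compounds. Nothing available here accounts for this. On these data alone, it remains open whether morpholin-4-yl or dimethylamino at this position, with carbamoyl kept, would give a number nearer that of compound 2. As far as these compounds go, how methoxy behaves alongside a nitrile also remains open.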